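Cyano on the phenylpiperazine of a benzamide series

A few compounds are considered here, and "the series" means these few. Any claim that something is new, unique, unknown or untested is made for them only; others in the source may bear on it.

Three compounds of this series share a benzamide core and are compared in a functional assay on HeLa cells (Homo sapiens) for antiproliferative activity, read by CCK-8 assay, with a stated time of 72 h, tested at 8 uM; on this read-out lower numbers stand for a weaker effect and higher numbers for a stronger effect at the one concentration tested. Compound 1 `Nc1ccccc1NC(=O)c1ccc(CSC(=S)N2CCN(C(c3ccccc3)c3ccccc3)CC2)cc1` gives 13.8% in this assay. Compound 2 `Nc1ccccc1NC(=O)c1ccc(CSC(=S)N2CCN(c3ccccc3)CC2)cc1` gives 73.1% in this assay. Compound 3 `Nc1ccccc1NC(=O)c1ccc(CSC(=S)N2CCc3ccccc32)cc1` gives 67% in this assay. On these numbers compound 2 stands highest of the three, but the number of compound 3 lies within the scatter of it, so no order between compound 2 and compound 3 can be read; only compound 1 lies beyond the scatter, well below compound 2.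

Compound 4 `N#Cc1ccc(N2CCN(C(=S)SCc3ccc(C(=O)Nc4ccccc4N)cc3)CC2)cc1` has not yet been measured. It differs from compound 2 in one place: cyano in place of hydrogen on an aromatic carbon. The same difference, cut one bond further out, reads phenyl to 4-cyanophenyl.

Going by the values given here, no step between measured compounds of this kind is available, so the expectation rests on compound 2 alone. A small step is expected, and none beyond the scatter is counted on, in either direction. The step from compound 2 to compound 4 is estimated as a number 3.1 percentage points lower from compound 2 to compound 4 (within the scatter). Compound 4 is expected to give about 70% in this assay, with a range from 50% to 86%.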

Compound 4, a percentage reported as inhibition, at one concentration (the size of the read-out at that concentration, not a potency): 70.6%
Compound 4: middle estimate off by 0.6 percentage points, on the low side, within the range that was stated.
By their numbers in this assay, from the lowest: compound 1; then compounds 3, 4 and 2 (each within the scatter of the next).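

Phenyl to 4-cyanophenyl is the only one-place change that can be read so far in this series, and in this assay it comes out as a number 2.5 percentage points lower from compound 2 to compound 4 (within the scatter) on the shared core. Going by these compounds alone, the earlier compounds offered no such step, so this is the first direct reading at this position: the aromatic carbon para to a large group carries a cyano group with no step beyond the scatter, in either direction, at the one concentration tested. Nothing measured here bears on what lies behind this result.

A single substituent at a single position is too little to show how far this tolerance extends: an amine, a methoxy group or a carboxylic acid at the same carbon, or a cyano group elsewhere on the same ring, could each read differently. Since this assay is a reading at one concentration, the values also leave open whether compound 2 and compound 4 would match in potency across a range of concentrations.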